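Compound 3: cyclopropyl in place of 3-hydroxypropyl

The source may hold more compounds than are shown below. What is called first, only, known or untested is meant among the compounds shown, and "the series" means these compounds.

For the measured compounds named here, in a functional assay on MDA-MB-231 cells (Homo sapiens) for inhibition, read by sulforhodamine B assay, with a stated time of 48 h (on this read-out higher numbers stand for weaker inhibition of growth and lower numbers for stronger inhibition of growth), compound 2 `COc1ccc2c(c1)NC(=O)CN2c1nc(NCCCO)nc2ccccc12` gives 10.2 nM, the lower of the two numbers so far. Compound 1 `COc1ccc2c(c1)NC(=O)CN2c1nc(OCC2CC2)nc2ccccc12` gives 45.2 nM in this assay.

The next analogue, compound 3 `COc1ccc2c(c1)NC(=O)CN2c1nc(NC2CC2)nc2ccccc12`, carries cyclopropyl in place of 3-hydroxypropyl on a nitrogen on an aromatic ring.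

Going by the values given here, only one measured step bears on this change: a 4.4-fold lower number from compound 1 to compound 2 (0.65 log units; beyond the scatter). That step put (3-hydroxypropyl)amino in place of cyclopropylmethoxy on an aromatic carbon, so the group and its link to the core changed together. Among the compounds with values here, no measured pair isolates a change on the nitrogen alone. Compound 3 shares the nitrogen link with compound 2 and a three-membered ring with compound 1, so a number between those of the two measured compounds is the working expectation, with a step smaller than the one already seen.

The expected move is a 2.2-fold higher number from compound 2 to compound 3 (0.33 log units; beyond the scatter), a small one toward a higher number. For compound 3 the estimated value is 22 nM, with an expected range of 6 nM to 75 nM.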

Compound 3, concentration for 50% growth inhibition: 10.5 nM
Compound 3: the middle estimate sits 2.1-fold (0.32 log units) above what was measured; the measured number falls inside the stated range.
By their numbers in this assay, from the lowest: compounds 2 and 3 (each within the scatter of the next); then compound 1.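

In this assay there is a 1.0-fold higher number from compound 2 to compound 3 (0.01 log units; within the scatter), so on a nitrogen on an aromatic ring, 3-hydroxypropyl and cyclopropyl stand level, and the hydrogen-bond donor and acceptor counted on 3-hydroxypropyl are not required to reach this level. With the cyclopropyl ring present in both compounds, the other new comparison gives a 4.3-fold lower number from compound 1 to compound 3 (0.63 log units; beyond the scatter), which shows that cyclopropylamino in place of cyclopropylmethoxy on an aromatic carbon carries a step beyond the scatter, even though the two groups still differ in more than the linking atom; compounds 2 and 3, both linked through nitrogen, thus both stand apart from compound 1 in this small set. No measured evidence accounts for either result.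

The compounds shown leave open how far this level extends on the nitrogen, for instance to a longer chain, a chain ending in a carboxylic acid, or a phenyl ring. They also leave open whether a plain amino group, or a dimethylamino group with no hydrogen left on the nitrogen, would stand with compounds 2 and 3 or with compound 1.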